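The compounds below may be only part of what the source reports. "The series", "measured", "known", "first", "only" and "open" are said of these compounds alone.

In an ADME assay on HepG2 cells (Homo sapiens) for cytotoxicity, read by luminescence, CellTiter-Glo and ATP content, with a stated time of 72 h (on this read-out lower numbers stand for an effect already at smaller amounts and higher numbers for an effect only at larger amounts of compound), three compounds of the series have been measured:

compound 1, `COc1cccc(CNCCCNc2ccnc3cc(Oc4ccccc4)ccc23)c1O`: 6800 nM
compound 2, `COc1cccc(CNCCCNc2ccnc3cc(Cc4ccc(C#N)cc4)ccc23)c1O`: 7150 nM
compound 3, `COc1cccc(CNCCCNc2ccnc3cc(-c4ccc(F)cc4)ccc23)c1O`: 6840 nM

Compound 3 has the second highest of the three numbers; its nearest neighbour is compound 1 and its furthest compound 2, and both gaps sit within the scatter, so the three read as one level.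

Compound 4, `COc1cccc(CNCCCNc2ccnc3cc(CCc4ccccc4)ccc23)c1O`, has not yet been measured in this assay. Relative to compound 3 it carries phenethyl in place of 4-fluorophenyl on an aromatic carbon. Within the data shown here, the steps that bear on such a replacement of the pendant group on the shared core are a 1.0-fold higher number from compound 1 to compound 3 (0.00 log units; within the scatter) and a 1.0-fold lower number from compound 2 to compound 3 (0.02 log units; within the scatter), together with a 1.1-fold higher number from compound 1 to compound 2 (0.02 log units; within the scatter); each exchanges one pendant group for another at the same aromatic carbon, and none moved the number beyond the scatter. Among the measured compounds shown here, a phenethyl at this position has no direct precedent here, but on the evidence of these three exchanges no step beyond the scatter is expected in this assay in either direction.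

Compound 4 is therefore expected at about 6900 nM, with a range of 3400 nM to 14000 nM. The expected step is a 1.0-fold higher number from compound 3 to compound 4 (0.00 log units; within the scatter).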

Compound 4, half-maximal effective concentration: 6800 nM
Compound 4: the middle estimate sits 1.0-fold (0.01 log units) above what was measured; the measured number falls inside the stated range.
By their numbers in this assay, from the lowest: compounds 1, 4, 3 and 2 (each within the scatter of the next).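

In this assay phenethyl behaves like the other pendant groups at this aromatic carbon (a 1.0-fold lower number from compound 3 to compound 4 (0.00 log units; within the scatter)) (a 1.1-fold lower number from compound 2 to compound 4 (0.02 log units; within the scatter)) (no change at the digits printed from compound 1 to compound 4 (within the scatter)). A saturated carbon chain between the core and the terminal ring therefore joins the direct bond, the ether oxygen of phenoxy and the single carbon of 4-cyanobenzyl, and all four compounds read as one level, with none going against it. No supporting data are available to explain this flat picture.

Every group shown at this place ends in an aromatic ring, so the effect of an amine, a carboxylic acid, plain hydrogen or a chain longer than phenethyl remains open. From the compounds shown here alone, all four compounds also share the rest of the structure, so whether this level holds after a change elsewhere on the shared core remains open too.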